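Does Redrawing Stereochemistry Rouse an Inactive Compound?

A few compounds are considered here, and "the series" means these few. Any claim that something is new, unique, unknown or untested is made for them only; others in the source may bear on it.

Measured so far in a functional assay on BV-2 cells (Mus musculus) for inhibition, read by Griess assay, with a stated time of 24 h (on this read-out lower numbers stand for stronger inhibition and higher numbers for weaker inhibition), each value being a limit of the assay:
- compound 1 (`CC(/C=C/[C@@H]1[C@@H](C(C)(C)O)CC[C@@]1(C)O)=C\[C@H]1C[C@@]23[C@H](OCCC[C@@H]2/C(=C(\C)C=O)CC[C@]3(C)O)O1`) gives > 10000 nM as a limit
- compound 2 (`C/C(C=O)=C1\CC[C@](C)(O)[C@]23C[C@H](/C=C(C)/C=C/[C@@H]4[C@@H](C(C)(C)O)CC[C@@]4(C)O)O[C@H]2OCCC[C@H]13`) gives > 10000 nM as a limit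

Compound 2 has no true number of its own, only (the limit of > 10000 nM in this assay, at which 2 of the 2 values shown sit), so how far it really lies from any active compound cannot be read.

The next candidate, compound 3 (`CC(/C=C/[C@H]1[C@H](C(C)(C)O)CC[C@]1(C)O)=C\[C@H]1C[C@@]23[C@H](OCCC[C@@H]2/C(=C(\C)C=O)CC[C@]3(C)O)O1`), keeps every atom of compound 2 and changes only in its drawn arrangement in space (the two compounds have the same atoms and bonds and differ only in configuration as drawn: 4 of 11 stereo elements differ; a stereocentre at a saturated ring carbon is drawn R in compound 2 and S in compound 3; a stereocentre at a saturated ring carbon is drawn S in compound 2 and R in compound 3; a stereocentre at a saturated ring carbon is drawn R in compound 2 and S in compound 3; a double bond is drawn Z in compound 2 and E in compound 3).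

Going by the values given here, only one measured step bears on this: a step that the two limits leave unreadable from compound 1 to compound 2. It is relevant through (the fact that compounds 1 and 2 differ only in the configuration as drawn), yet it gives no size to build on, and it involved fewer changed stereo elements than the new step does. With no readable precedent, no step beyond the scatter is expected in this assay, and no direction can be argued.

The estimated step, a step that the limit leaves unreadable from compound 2 to compound 3, therefore stays an expectation with wide margins. For compound 3 the expected value is about 12000 nM, with an estimated range from 5000 nM to 30000 nM, and the assay may well report only a limit again.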

Compound 3, half-maximal inhibitory concentration: > 10000 nM
Compound 3 was reported as a limit (the forecaster's own chance of this, stated with the estimate: 75%); the middle value is on the limit's open side.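

Going by these compounds alone, no step among compound 1, compound 2 and compound 3 can be read, since none of them has a true number, only a limit: the limit of > 10000 nM in this assay, at which 3 of the 3 values shown sit. The compounds shown leave open what the true value of each one is in this assay, and whether their different arrangements in space change that value at all.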